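The source may hold more compounds than are shown below. What is called first, only, known or untested is meant among the compounds shown, and "the series" means these compounds.

Among the measured compounds shown here, compound 1 `C[C@H](Nc1ncnc2[nH]cnc12)c1cc2ccccn2c(=O)c1-c1ccccc1` gives 100% in an ADME assay on microsomes from liver (Homo sapiens), read by LC-MS, using NADPH, with a stated time of 30 min, tested at 1 uM (a lower number here means that less of the compound is left, a higher number that more of the compound is left), the highest of the three numbers so far. Compound 3 `Cc1c(F)ccc2cc([C@H](C)Nc3ncnc(N)c3C#N)c(-c3ccccc3)c(=O)n12` gives 89% in this assay, and compound 2 `Cc1cccc2cc([C@H](C)Nc3ncnc4[nH]cnc34)c(-c3ccccc3)c(=O)n12` gives 70% in this assay. For the measured compounds named here, only one measured pair differs in a single place, and that step was a number 30 percentage points lower from compound 1 to compound 2 (beyond the scatter). Compound 4 `C[C@H](Nc1ncnc2[nH]cnc12)c1cc2ccc(F)cn2c(=O)c1-c1ccccc1` differs from compound 1 by fluoro in place of hydrogen on an aromatic carbon. Going by the values given here, no measured step involves a fluoro at that place; the one step that bears on it is the methyl-for-hydrogen change, also a single group entering on an aromatic carbon of the shared core, which lowered the number modestly. A small decrease is therefore expected, a number 10 percentage points lower from compound 1 to compound 4 (within the scatter), possibly within the scatter. Compound 4 is estimated at 90%, with a range from 75% to 100%.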

Compound 4, percent of the compound remaining: 98%
For compound 4 the middle estimate is 8 percentage points below the measured one, and the stated range covers the measured number.
By their numbers in this assay, from the lowest: compound 2; then compounds 3, 4 and 1 (each within the scatter of the next, the first and the last beyond it).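

Fluoro in place of hydrogen on this aromatic carbon, two atoms from the ring nitrogen, leaves the read-out in this assay essentially unchanged, with a number 2 percentage points lower from compound 1 to compound 4 (within the scatter) as the step. This differs from the step for methyl at another place on the shared core, a number 30 percentage points lower from compound 1 to compound 2 (beyond the scatter), so a single group entering this core need not lower the number beyond the scatter. Nothing available explains this result. Open, from the compounds shown here alone, is whether an amine, methoxy or trifluoromethyl at this place would also leave the number within the scatter. Also open, going by these compounds, is whether fluoro behaves alike on the other aromatic carbons of the core.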